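From ethyl to cyclohexylmethyl on the amine

A few compounds are considered here, and "the series" means these few. Any claim that something is new, unique, unknown or untested is made for them only; others in the source may bear on it.

Compound 1 `CCCN(Cc1ccc(OCCN2C(=O)CCC2=O)c(C)c1)[C@@H](CC(=O)O)c1ccc(Cl)cc1`: 9.3 nm/s
Compound 2 `CCN(Cc1ccc(OCCN2C(=O)CCC2=O)c(C)c1)C(CC(=O)O)c1ccc(Cl)cc1`: 3.9 nm/s
Compound 3 `Cc1cc(CN(CC2CCCC2)[C@@H](CC(=O)O)c2ccc(Cl)cc2)ccc1OCCN1C(=O)CCC1=O`: 18.1 nm/s

These three numbers come from an ADME assay on Caco-2 cells (Homo sapiens) for permeability, read by LC-MS, with a stated time of 2 h; on this read-out lower numbers stand for lower permeability and higher numbers for higher permeability. Compound 2, at 3.9 nm/s, stands lowest of the three, and its gaps to compound 1 and compound 3 both lie beyond the usual scatter.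

The next compound to be measured is compound 4 `Cc1cc(CN(CC2CCCCC2)C(CC(=O)O)c2ccc(Cl)cc2)ccc1OCCN1C(=O)CCC1=O`. Its difference from compound 2 is cyclohexyl in place of methyl on a saturated chain carbon bound to an amine nitrogen. In words, this is cyclohexyl in place of methyl on a saturated chain carbon bound to an amine nitrogen, which can also be read as ethyl to cyclohexylmethyl.

The closest measured change is a 1.9-fold higher number from compound 1 to compound 3 (0.29 log units; within the scatter), where cyclopentyl replaces ethyl at the same kind of carbon. That step stays within the scatter, so it shows no clear change on its own. Among the compounds with values here, no measured compound carries cyclohexyl here, so compound 3, at 18.1 nm/s, is the nearest guide.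

The expected change is a 4.6-fold higher number from compound 2 to compound 4 (0.66 log units; beyond the scatter), upward and beyond the scatter. For compound 4 the estimated value in this assay is 18 nm/s, with an expected range of 8 nm/s to 40 nm/s.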

Compound 4, apparent permeability: 83.9 nm/s
Compound 4: middle estimate off by 4.7-fold (0.67 log units), on the low side; measured number outside the range, above it.
By their numbers in this assay, from the lowest: compound 2; then compounds 1 and 3 (each within the scatter of the next); then compound 4.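

In this assay, the step of a 22-fold higher number from compound 2 to compound 4 (1.33 log units; beyond the scatter) is large, whereas the earlier step at the same kind of carbon, a 1.9-fold higher number from compound 1 to compound 3 (0.29 log units; within the scatter), stayed within the scatter. This shows that a change on this saturated chain carbon bound to the amine nitrogen can shift the number clearly, something the earlier step alone could not establish. No measurement shown here gives a cause for the size of this step.

Still open, on these data alone, is whether the rise depends on the six-membered carbon ring itself or would also appear with an open chain such as n-heptyl. A tetrahydropyranylmethyl group at the same place, with an oxygen in the ring, would test whether an all-carbon ring is needed for a number this high.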